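A few compounds are considered here, and "the series" means these few. Any claim that something is new, unique, unknown or untested is made for them only; others in the source may bear on it.

Of the compounds shown here, three that share one core have been measured in an ADME assay on microsomes from liver (Mus musculus) for metabolic stability, read by LC-MS, using NADPH, with a stated time of 10 min, tested at 10 uM; a higher number here means that the compound lasts longer, a lower number that the compound disappears faster. Compound 1 `Nc1ncnc2c1c(Oc1cc(C(F)(F)F)ccn1)nn2[C@H]1CC[C@@H](N)CC1` gives 0.917 h, and compound 2 `Nc1ncnc2c1c(Oc1cc(O)ccn1)nn2C1CCC(F)(F)CC1` gives 1.13 h. These two numbers lie within the usual scatter of each other, so compound 2 stands level with compound 1 and the two cannot be ranked. Compound 3 `N#Cc1ccnc(Oc2nn([C@H]3C[C@H](O)C3)c3ncnc(N)c23)c1` reads > 2.41 h, which is a limit of the assay and not a number.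

Compound 4 `Nc1ncnc2c1c(Oc1cc(O)ccn1)nn2[C@H]1C[C@H](F)C1` keeps compound 2 intact except in one place. On an aromatic nitrogen of the core, 3-fluorocyclobutyl stands in place of 4,4-difluorocyclohexyl (3-fluorocyclobutyl in place of 4,4-difluorocyclohexyl on an aromatic nitrogen). Going by the values given here, no two measured compounds differ in just one place, so no measured step speaks directly to this change. The closest hint is compound 3, which also has a four-membered ring on that nitrogen and shows the limit > 2.41 h, although it also differs from compound 4 in its other substituent. On that slender basis, the estimated step in this assay is a 1.4-fold higher number from compound 2 to compound 4 (0.15 log units; within the scatter), a modest rise that may well stay within the scatter. For compound 4 the estimate is 1.6 h, with an expected range of 0.8 h to 3.2 h.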

Compound 4, half-life: 0.267 h
For compound 4 the middle estimate is 6.0-fold (0.78 log units) above the measured one, outside the stated range (below it).
By their numbers in this assay, from the lowest: compound 4; then compounds 1 and 2 (each within the scatter of the next). At a limit, above all of these: compound 3.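

In this assay, going by these compounds alone, a 4.2-fold lower number from compound 2 to compound 4 (0.63 log units; beyond the scatter), the first step in the set that can be read at one place, and it shows that the group on this aromatic nitrogen can shift the half-life beyond the scatter while the rest of the molecule stays the same. A four-membered ring here therefore does not by itself bring a long half-life, since compound 4 carries one and sits lowest of the measured numbers. Compound 3 also has a four-membered ring on this nitrogen, but it differs from compound 4 in a second place as well, and its reading is a limit of the assay and not a number: the limit of > 2.41 h in this assay, at which 1 of the 4 values shown sits.

This single step swaps ring size and fluorine count together, so it cannot say which of the two goes with the shorter half-life, and a plain cyclobutyl or a cyclopentyl group on the same nitrogen would be needed to pull them apart. It also leaves open whether the same swap gives a step of similar size when a trifluoromethyl or nitrile group replaces the hydroxyl of the (4-hydroxypyridin-2-yl)oxy group.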